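Moving the methoxyphenyl ring and dropping its oxygen link

This account rests on a few compounds, and the source may have more. Where it says the series, first, only, none or still open, it means among the compounds named here.

Compound 1 `COc1cccc(Oc2ccc3c(NCCCNCc4ccco4)ccnc3c2)c1` gives 9.28 in a physicochemical assay for acid dissociation. Compound 2 `COc1ccccc1Oc1ccc2c(NCCCNCc3ccco3)ccnc2c1` gives 9.28, and the step of no change at the digits printed from compound 1 to compound 2 (within the scatter) shows that changing where the methoxy group sits on that outer ring left the number alone. Compound 3 `COc1ccc(-c2ccc3c(NCCCNCc4ccco4)ccnc3c2)cc1` differs from compound 2 in this way: 4-methoxyphenyl in place of 2-methoxyphenoxy on an aromatic carbon. Among the compounds with values here, only that one measured step bears on the change, and it was flat, so no shift beyond the scatter is expected here, with a number 0.02 log units higher from compound 2 to compound 3 (within the scatter) as the estimated step. Compound 3 is therefore expected to give 9.3, within 9 to 9.6.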

Compound 3, acid dissociation constant: 9.47
Compound 3: middle estimate off by 0.17 log units, on the low side; measured number inside the range.
By their numbers in this assay, from the lowest: compounds 1, 2 and 3 (each within the scatter of the next).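

This is a larger change than moving the methoxy group alone: the oxygen link goes and the methoxy group moves as well. Even so, this assay stays within the scatter (a number 0.19 log units higher from compound 2 to compound 3 (within the scatter); a number 0.19 log units higher from compound 1 to compound 3 (within the scatter)). The 4-methoxyphenyl and both methoxyphenoxy groups therefore cannot be told apart at this position by this read-out, and nothing available explains the result.

Because the link and the methoxy position change together here, their separate contributions cannot be read. As far as these compounds go, whether an amine or a carboxylic acid at this position would move the number remains open.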